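Replacing 4-(dimethylamino)phenyl with 2-chlorophenyl

The compounds below may be only part of what the source reports. "The series", "measured", "known", "first", "only" and "open" are said of these compounds alone.

In a functional assay on MCF7 cells (Homo sapiens) for cytotoxicity, read by MTT assay, with a stated time of 24 h (a higher number here means a weaker inhibitor, a lower number a stronger inhibitor), compound 1 (`C/C(=N\NC(=O)/C(C#N)=C/c1ccccc1)c1c(O)c2ccc(O)cc2oc1=O`) gives 19200 nM and compound 2 (`COc1cc(/C=C(\C#N)C(=O)N/N=C(\C)c2c(O)c3ccc(O)cc3oc2=O)cc(OC)c1OC`) gives 11300 nM, while compound 3 (`C/C(=N\NC(=O)/C(C#N)=C/c1ccc(N(C)C)cc1)c1c(O)c2ccc(O)cc2oc1=O`) gives 3420 nM as the lowest of the three numbers. Compound 4 (`C/C(=N\NC(=O)/C(C#N)=C/c1ccccc1Cl)c1c(O)c2ccc(O)cc2oc1=O`) has 2-chlorophenyl in place of 4-(dimethylamino)phenyl on a double-bonded chain carbon bound to a double-bonded chain carbon. Among the measured compounds shown here, the one measured step bearing on this is a 5.6-fold lower number from compound 1 to compound 3 (0.75 log units; beyond the scatter) (dimethylamino in place of hydrogen on an aromatic carbon), modest in size, and compound 4 lacks that dimethylamino group. For the measured compounds named here, no measured compound carries chlorine. A step of comparable size towards a higher number is therefore expected in this assay, estimated as a 3.8-fold higher number from compound 3 to compound 4 (0.58 log units; beyond the scatter) for now. For compound 4 the estimated value is 13000 nM with an expected range from 5500 nM to 30000 nM in this assay series.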

Compound 4, half-maximal inhibitory concentration: 8880 nM
The estimate for compound 4 lay 1.5-fold (0.17 log units) above the measured number; the range from low to high includes it.
By their numbers in this assay, from the lowest: compound 3; then compounds 4, 2 and 1 (each within the scatter of the next, the first and the last beyond it).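

In this assay chloro in place of hydrogen gives a 2.2-fold lower number from compound 1 to compound 4 (0.33 log units; beyond the scatter) and so a lower number at this aryl group is not confined to dimethylamino. Even so, 2-chlorophenyl does not match 4-(dimethylamino)phenyl on this chain carbon, with a 2.6-fold higher number from compound 3 to compound 4 (0.41 log units; beyond the scatter) as the result of the exchange. No supporting data explain either step.

The two groups differ in both identity and ring position, so these compounds cannot separate those effects. As far as these compounds go, whether a morpholine or a carboxylic acid on the phenyl ring would give a number below that of compound 3 remains open.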